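A few compounds are considered here, and "the series" means these few. Any claim that something is new, unique, unknown or untested is made for them only; others in the source may bear on it.

So far two compounds sharing one core have been measured in an in vivo ADME assay on the whole organism for metabolic stability, with Rattus norvegicus as the target; on this read-out higher numbers stand for a longer-lived compound and lower numbers for a shorter-lived compound. Compound 1 `CC1(C)C=C(c2cc(-c3ccc(F)cc3Cl)c3ccc(=O)n(-c4c(Cl)cccc4Cl)c3c2)CC(C)(C)N1` gives 3.17 h, and compound 2 `CC(C)(C)N1CCC(c2cc(-c3ccc(F)cc3Cl)c3ccc(=O)n(-c4c(Cl)cccc4Cl)c3c2)CC1` gives 3.5 h. These two numbers lie within the scatter of each other, so compound 2 sits level with compound 1 on present evidence.

The next compound, compound 3 `CC(C)(C)N1CCC(c2cc(-c3ccc(F)cc3F)c3ccc(=O)n(-c4c(Cl)cccc4Cl)c3c2)CC1`, keeps everything in compound 2 except one halogen on the outer aromatic ring: fluoro in place of chloro on an aromatic carbon. Seen one bond further out, this turns 2-chloro-4-fluorophenyl into 2,4-difluorophenyl.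

Among the measured compounds shown here, no measured pair tests this exchange directly. For the measured compounds named here, the only measured step, a 1.1-fold higher number from compound 1 to compound 2 (0.04 log units; within the scatter), swaps a different group at another place on the molecule, so it bears on the question only loosely. It lies within the scatter and offers no sign of a large shift. With so little to go on, no change beyond the scatter is expected in this assay, and the estimated step is a 1.1-fold lower number from compound 2 to compound 3 (0.03 log units; within the scatter). The expected half-life of compound 3 is 3.3 h, with an estimated range from 1.6 h to 6.5 h.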

Compound 3, half-life: 4.13 h
Compound 3: middle estimate off by 1.3-fold (0.10 log units), on the low side; the range from low to high includes it.
By their numbers in this assay, from the lowest: compounds 1, 2 and 3 (each within the scatter of the next).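

In this assay the exchange of chloro for fluoro, at the place ortho to a large group on the outer ring, gives a 1.2-fold higher number from compound 2 to compound 3 (0.07 log units; within the scatter) and so produces no shift that can be told from the scatter. Among the compounds shown here, this is the first direct reading of this exchange, since the earlier step concerned a different group at another place on the molecule, and it shows that, in this pair, the chloro group at this position can give way to fluoro without a clear loss or gain in half-life. Nothing measured here explains why the half-life holds level across this exchange.

Going by these compounds, whether a hydrogen, a methyl group or a methoxy group at this same position would also leave the half-life within the scatter remains open, and a larger group such as trifluoromethyl might read differently. For the compounds shown here, also open is whether fluoro in place of chloro would read the same way with the six-membered ring of compound 1 in place of the one carried by compound 2.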